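A few compounds are considered here, and "the series" means these few. Any claim that something is new, unique, unknown or untested is made for them only; others in the source may bear on it.

Working notes on the series in an assay on HEK293 cells for activation of Kir3.1/Kir3.2 (Homo sapiens), read by thallium flux; on this read-out higher numbers stand for an effect only at larger amounts of compound and lower numbers for an effect already at smaller amounts. Compound 1 `Cc1cc(NC(=O)Cn2nnc(-c3ccccc3)n2)n(C(C)C)n1` carries an isopropyl group on an aromatic nitrogen of the shared core, and in this assay compound 1 gives 556 nM. Compound 2 `Cc1cc(NC(=O)Cn2nnc(-c3ccccc3)n2)n(C2CC2)n1` carries a cyclopropyl group at that position instead. For compound 2 this assay returns only a limit, > 5000 nM, so compound 2 stands at the weak end of the two results shown without a number of its own. The step of an at least 8.9-fold higher number from compound 1 to compound 2 (0.95 log units; beyond the scatter) rests on the limit of > 5000 nM in this assay, at which 1 of the 2 values shown sits, and therefore gives a minimum size only. Compound 3 `Cc1cc(NC(=O)Cn2nnc(-c3ccccc3)n2)n(-c2ccccc2)n1` is the next member: phenyl in place of cyclopropyl on an aromatic nitrogen. Among the compounds with values here, only the step from compound 1 to compound 2 bears on this change; it concerns the same position but a different pair of groups, so it sets no direction for a phenyl group here, and the start point is already a limit. The expectation is therefore a step of about a number no higher from compound 2 to compound 3 (the limit leaves the size open) in this assay, that is, none beyond the scatter, with a fair chance that compound 3 again returns only a limit. Compound 3 is accordingly estimated at 5000 nM, within 1500 nM to 20000 nM.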

Compound 3, half-maximal effective concentration: 3020 nM
Compound 3: the middle estimate sits 1.7-fold (0.22 log units) above what was measured; the range from low to high includes it.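

Within the data shown here, compound 3 gives this position its second number in this assay, and with it the first step here whose size is fully read: a 5.4-fold higher number from compound 1 to compound 3 (0.73 log units; beyond the scatter). Among the three groups, isopropyl therefore keeps the lowest number, with both steps away from compound 1 beyond the scatter, while an aromatic ring on this nitrogen still gives a measurable effect that lies on the weaker side of compound 1. Phenyl and cyclopropyl cannot be put in a firm order, since the step of an at least 1.6-fold lower number from compound 2 to compound 3 (0.21 log units; that floor lies within the scatter) gives only a floor, and compound 2 has a limit rather than a number of its own: the limit of > 5000 nM in this assay, at which 1 of the 3 values shown sits.

Three groups on one nitrogen do not show whether the trend among them depends on the size of the group, on branching or on the ring type, and a tert-butyl group, an ethyl group or a phenyl ring carrying a fluorine or a methoxy group would be needed to separate these. On these data alone, whether any group at this position can reach a lower number than isopropyl stays open, as does the part played by the methyl group on the shared core, which is the same in all three compounds.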